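The source may report more compounds than this note shows. Statements on the series, on what has been measured and on what is new or still open speak of the compounds shown alone.

Compound 1 `O=c1cc(-c2cccc(-c3ccccc3)c2)c2cccnc2n1O`: > 50000 nM
Compound 2 `O=c1ccc2cccnc2n1O`: 20000 nM

Both compounds were tested in an ADME assay on HeLaP4-2 cells (Homo sapiens) for cytotoxicity, read by resazurin assay; a higher number here means that more compound is tolerated, a lower number that less compound is tolerated. For compound 1 the reported value is a limit of the assay, not a number, so compound 1 stands at the limit of > 50000 nM in this assay, at which 1 of the 2 values shown sits. Compound 2 gives 20000 nM in this assay. Compound 3 `NCc1ccccc1-c1cccc(-c2cc(=O)n(O)c3ncccc23)c1` differs from compound 1 by aminomethyl in place of hydrogen on an aromatic carbon. Going by the values given here, no step between two measured compounds is known, so the expectation rests on compound 1 alone: little or no change beyond the usual scatter is expected, an at least 1.2-fold lower number from compound 1 to compound 3 (0.09 log units; that floor lies within the scatter). Compound 3 is estimated at 40000 nM, within a range from 15000 nM to 100000 nM.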

Compound 3, half-maximal cytotoxic concentration: 9100 nM
The estimate for compound 3 lay 4.4-fold (0.64 log units) above the measured number; measured number outside the range, below it.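

In this assay, the change from phenyl to 2-(aminomethyl)phenyl gives an at least 5.4-fold lower number from compound 1 to compound 3 (0.73 log units; beyond the scatter), so this position on the outer ring affects how much compound the cells tolerate. Compound 1 has only a limit and not a number, so the true step could be larger: the limit of > 50000 nM in this assay, at which 1 of the 3 values shown sits.

The compounds shown leave open whether the nitrogen matters or whether any group here would have the same effect. A methyl, a hydroxymethyl or a longer aminoethyl chain at this place could separate these possibilities.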